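The compounds below may be only part of what the source reports. "The series", "measured", "known", "first", "only" and "open" are said of these compounds alone.

Measured compounds in a functional assay on HCT-15 cells (Homo sapiens) for cytotoxicity, read by CCK-8 assay and cell counting, with a stated time of 72 h; a lower number here means a stronger inhibitor, a higher number a weaker inhibitor:
compound 1, structure `COc1cc(OC)cc(-c2cc3ccccc3c(-c3ccc(O)cc3)n2)c1`, value 2780 nM in this assay
compound 2, structure `COc1ccc(-c2cc3cc(C)ccc3c(-c3cccc(N)c3)n2)cc1OC`, value 2700 nM in this assay

Compound 2 has the lower of the two numbers in this assay, but its nearest neighbour is compound 1 and the gap between them falls within the scatter of repeated measurements, so no order between the two can be read from these values. Among the measured compounds shown here, no step between compounds that differ in a single place is available so far.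

The next compound, compound 3 with structure `COc1ccc(-c2nc(-c3ccc(OC)c(OC)c3)cc3cc(C)ccc23)cc1`, is not yet measured. It differs from compound 2 by 4-methoxyphenyl in place of 3-aminophenyl on an aromatic carbon on the shared core. Nothing in the measured pair tells how this assay responds to such a swap, so the step is expected to stay within the scatter in either direction, with no clear direction favoured. For compound 3 the estimate in this assay is therefore 3000 nM with a range from 1000 nM to 9000 nM, which corresponds to an expected step of a 1.1-fold higher number from compound 2 to compound 3 (0.05 log units; within the scatter) in this assay.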

Compound 3, half-maximal inhibitory concentration: 28700 nM
Compound 3: the middle estimate sits 9.6-fold (0.98 log units) below what was measured; the whole stated range lies below it.
By their numbers in this assay, from the lowest: compounds 2 and 1 (each within the scatter of the next); then compound 3.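

In this assay, among the compounds shown here, the group on the aromatic carbon next to the ring nitrogen of the shared core proves able to shift the read-out: 4-methoxyphenyl in place of 3-aminophenyl gives an 11-fold higher number from compound 2 to compound 3 (1.03 log units; beyond the scatter), the first single-place step, as compound 1 and compound 2 differ in more than one place. The leaving group has 1 hydrogen-bond donor and the entering group has 0, while each has 1 hydrogen-bond acceptor, but the swap also changes both the substituent and its place on the phenyl ring, so this one step cannot assign the loss to any single feature. No measurement at hand accounts for the size of this step.

The compounds shown leave open whether 3-methoxyphenyl or 4-aminophenyl at this position would stay close to compound 2 or compound 3, which would separate the identity of the substituent from its place on the ring. Also open, going by these compounds, is how this position responds to a phenyl ring carrying a carboxylic acid or a dimethylamino group.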